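The source may hold more compounds than are shown below. What is called first, only, known or untested is meant among the compounds shown, and "the series" means these compounds.

Among the measured compounds shown here, only two compounds have a number so far in an ADME assay on microsomes from liver (Rattus norvegicus) for metabolic stability, read by HPLC, using NADPH; a higher number here means that the compound lasts longer, a lower number that the compound disappears faster. Compound 1 `CCn1c(C(=O)NCCN)ccc1C(CC)(CC)c1ccc(OCS(=O)(=O)c2ccccc2)c(C)c1` gives 0.582 h, and compound 2 `CCN(CC)CCNC(=O)c1cc(C(CC)(CC)c2ccc(OCSC)c(C)c2)cn1CC` gives 0.802 h. These two values lie within the usual scatter of each other, so compound 2 stands level with compound 1 on this evidence. The two structures also differ in more than one place, so their gap cannot be pinned on any single change.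

Compound 3 `CCN(CC)CCNC(=O)c1cc(C(CC)(CC)c2ccc(OCSc3ccccc3)c(C)c2)cn1CC` departs from compound 2 at one point, with phenyl in place of methyl on a sulfur. For the measured compounds named here, no measured pair shows this change on its own, so the size of the step has to be judged indirectly. Going by the values given here, the only guide is compound 1, which also holds a phenyl on a sulfur and gives 0.582 h, although much else in compound 1 differs as well. On that thin basis, a large change in this assay is not expected. The expected step is a small downward one, a 1.3-fold lower number from compound 2 to compound 3 (0.13 log units; within the scatter), which stays within the scatter. Compound 3 is estimated at 0.6 h, with a likely range from 0.25 h to 1.3 h.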

Compound 3, half-life: 1.19 h
Estimate against measurement, compound 3: 2.0-fold (0.30 log units) below; the range from low to high includes it.
By their numbers in this assay, from the lowest: compounds 1, 2 and 3 (each within the scatter of the next, the first and the last beyond it).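

In this assay, the change of phenyl in place of methyl on a sulfur can now be read directly, and it gives a 1.5-fold higher number from compound 2 to compound 3 (0.17 log units; within the scatter). This sulfur, whose other neighbour is a saturated chain carbon, can therefore carry a six-membered aromatic ring of carbon only instead of a single-carbon methyl without the number moving beyond the usual scatter of repeated measurements, so the two compounds stand level in this assay. Nothing available explains why the swap leaves the reading within the scatter, and a single pair cannot show whether the same would hold on another core.

Going by these compounds, what stays open is how much further the group on this sulfur can vary, for example whether an ethyl or a longer chain would also stay level with compound 2. Also open, on these data alone, is whether an amine or a carboxylic acid placed on the phenyl of compound 3 would keep the number level or take it beyond the scatter.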